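The source may hold more compounds than are shown below. What is called first, only, known or untested is meant among the compounds shown, and "the series" means these compounds.

Measured compounds:
- compound 1, `CNC(=O)/C=C/c1ccncc1-c1ccc2cc[nH]c2c1`: 18.6 nM
- compound 2, `O=C(/C=C/c1ccncc1-c1ccc2ncccc2c1)N1CCOCC1`: 1590 nM
- compound 3, `O=C(/C=C/c1ccncc1-c1ccc2cc[nH]c2c1)N1CCOCC1`: 43.9 nM

Three compounds were measured in an assay on a protein complex for inhibition of CDK8/Cyclin C (Homo sapiens), with a stated time of 1 h; on this read-out higher numbers stand for weaker inhibition and lower numbers for stronger inhibition. Compound 1 `CNC(=O)/C=C/c1ccncc1-c1ccc2cc[nH]c2c1` and compound 3 `O=C(/C=C/c1ccncc1-c1ccc2cc[nH]c2c1)N1CCOCC1` share one core and differ only at the amide end: in this assay compound 1 gives 18.6 nM and compound 3 gives 43.9 nM. The change between them is methylamino in place of morpholin-4-yl on a carbonyl carbon, and the step it made is a 2.4-fold lower number from compound 3 to compound 1 (0.37 log units; beyond the scatter).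

Compound 2 `O=C(/C=C/c1ccncc1-c1ccc2ncccc2c1)N1CCOCC1` carries a different core with the same (morpholin-4-yl)carbonyl end; in this assay compound 2 gives 1590 nM, the highest number of the three, far above compound 3 and compound 1. The difference between the two cores is not broken down here.

Compound 4 `CNC(=O)/C=C/c1ccncc1-c1ccc2ncccc2c1` has not been measured. It differs from compound 2 by methylamino in place of morpholin-4-yl on a carbonyl carbon, which is the same change that leads from compound 3 to compound 1, at the same place on the carbonyl carbon. The expectation for compound 4 rests on a single precedent: if the change behaves on the core of compound 2 as it did on the core of compound 3, the expected step is a 2.4-fold lower number from compound 2 to compound 4 (0.38 log units; beyond the scatter), set beside a 2.4-fold lower number from compound 3 to compound 1 (0.37 log units; beyond the scatter). Because the starting number for compound 2 is 1590 nM, compound 4 is expected to remain a weak inhibitor. The estimate for compound 4 in this assay is 660 nM, expected to fall between 250 nM and 1800 nM.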

Compound 4, half-maximal inhibitory concentration: 250 nM
Compound 4: middle estimate off by 2.6-fold (0.42 log units), on the high side, within the range that was stated.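

In this assay, methylamino in place of morpholin-4-yl on a carbonyl carbon again gave a lower number on the core of compound 2, with a 6.4-fold lower number from compound 2 to compound 4 (0.80 log units; beyond the scatter) in this series. The direction of the step therefore carried over from one core to the other, but its size did not, and the core of compound 2 gained more from the change than the core of compound 3: the same change on two cores in this assay, a 2.4-fold lower number (0.37 log units; beyond the scatter) from compound 3 to compound 1 and a 6.4-fold lower number (0.80 log units; beyond the scatter) from compound 2 to compound 4, 2.7-fold (0.43 log units) apart, beyond the scatter of two such steps. This shows that a step measured on one core gave the right direction but not a dependable size on the other, yet it does not show why the two steps differ, and a single pair of cores supports no general rule for how the change behaves on further cores.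

The compounds shown leave open whether the larger step on the core of compound 2 would recur on other cores, or whether it is particular to this pair. They also leave open how other groups on the same carbonyl carbon, such as ethylamino, dimethylamino, a piperidine ring or a longer amine chain, would behave on each of the two cores.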